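The source may hold more compounds than are shown below. What is called first, only, known or untested is meant among the compounds shown, and "the series" means these compounds.

Four compounds built around one shared core are considered here, in a functional assay on MCF7 cells (Homo sapiens) for antiproliferative activity, read by MTT assay, with a stated time of 72 h; a higher number here means a weaker inhibitor, a lower number a stronger inhibitor. Compound 1 is `O=c1cc(CC(O)(COCc2ccccc2)COCc2ccccc2)[nH]c(=O)[nH]1`. In this assay compound 1 gives > 100000 nM, which is a limit of the assay and not a number. Compound 2 is `COCn1c(CC(O)(COCc2ccccc2)COCc2ccccc2)cc(=O)[nH]c1=O`, and it differs from compound 1 in one place: methoxymethyl in place of hydrogen on an aromatic nitrogen. In this assay compound 2 gives > 100000 nM, again a limit rather than a number. The step that the two limits leave unreadable from compound 1 to compound 2 therefore cannot be read, because the limit of > 100000 nM in this assay, at which 2 of the 3 values shown sit, hides its size.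

Compound 3 is `COCn1c(=O)[nH]c(CC(COCc2ccccc2)COCc2ccccc2)c(C)c1=O`; how its core differs from the core of compound 1 is not broken down here. In this assay, among the measured compounds shown here, compound 3 gives 21600 nM, the only number among the three measured compounds.

Compound 4, `COCn1c(CC(COCc2ccccc2)COCc2ccccc2)c(C)c(=O)n(COC)c1=O`, has not yet been measured. It differs from compound 3 by methoxymethyl in place of hydrogen on an aromatic nitrogen. This is the same kind of change as that from compound 1 to compound 2, not the same: in compound 4 the place is also meta to a methoxymethyl group (3 heavy atoms) and meta to a methyl group (1 heavy atom), which is not so in compound 2. For the measured compounds named here, since the only earlier example of this change sits between two limits, its size is unknown, and the expected step of a 1.1-fold lower number from compound 3 to compound 4 (0.03 log units; within the scatter) is taken as small. Compound 4 is accordingly estimated at 20000 nM, between 6000 nM and 70000 nM.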

Compound 4, half-maximal inhibitory concentration: 400 nM
Compound 4: middle estimate off by 50-fold (1.70 log units), on the high side, outside the stated range (below it).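

In this assay, methoxymethyl in place of hydrogen on an aromatic nitrogen brings a 54-fold lower number from compound 3 to compound 4 (1.73 log units; beyond the scatter), so on the core of compound 3 this single change has a large effect. This is one readable step on one core, and it establishes no rule for the series: in compound 4 the new group is also meta to a methoxymethyl group (3 heavy atoms) and meta to a methyl group (1 heavy atom), which is not so in compound 2, and the data do not tell whether the size of the step depends on these surroundings. Whether the change does anything on the core of compound 1 stays unknown, because the step to compound 2 cannot be read, both of its ends being limits and not numbers: the limit of > 100000 nM in this assay, at which 2 of the 4 values shown sit.

The compounds shown leave open whether the step needs methoxymethyl itself or whether a plain ethyl group, a longer chain such as methoxyethyl, or a chain ending in an amine on the same nitrogen would do the same. They also leave open how the hydroxyl on the side chain and the methyl on the ring, taken one at a time, bear on the result.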